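The source may report more compounds than this note shows. Statements on the series, on what has been measured and on what is new or still open speak of the compounds shown alone.

Measured so far:
compound 1 `CCOCCn1c(N2CCN(C)CC2)nc2ccccc21` — 10 nM
compound 2 `CCNCCn1c(N2CCN(C)CC2)nc2ccccc21` — 290 nM
compound 3 `COCCCn1c(N2CCN(C)CC2)nc2ccccc21` — 860 nM

These values come from a functional assay on ileum for inhibition of histamine H1 receptor (Cavia porcellus); on this read-out lower numbers stand for stronger inhibition and higher numbers for weaker inhibition. Compound 3 gives the highest number of the three: the step of a 3.0-fold higher number from compound 2 to compound 3 (0.47 log units; beyond the scatter) and the step of an 86-fold higher number from compound 1 to compound 3 (1.93 log units; beyond the scatter) both lie beyond the scatter. Compound 4 `CN1CCN(c2nc3ccccc3[nH]2)CC1` differs from compound 3 by hydrogen in place of 3-methoxypropyl on an aromatic nitrogen. Going by the values given here, no measured step matches this change: the steps of a 29-fold higher number from compound 1 to compound 2 (1.46 log units; beyond the scatter) and an 86-fold higher number from compound 1 to compound 3 (1.93 log units; beyond the scatter) swap one group on the chain for another, but none removes the chain altogether. The known steps are large, so a sizable step is plausible in either direction, and the direction remains uncertain. On balance compound 4 is expected to give 1500 nM, with a range from 200 nM to 10000 nM. This estimate means a step of a 1.7-fold higher number from compound 3 to compound 4 (0.24 log units; within the scatter) in this assay.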

Compound 4, half-maximal inhibitory concentration: > 3000 nM
Compound 4: no number, only a limit; the forecaster's own chance of this, stated with the estimate: 15%; middle value at least 2.0-fold (0.30 log units) from the limit.
By their numbers in this assay, from the lowest: compound 1; then compound 2; then compound 3. At a limit, above all of these: compound 4.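

In this assay compound 4, which carries only hydrogen on the aromatic nitrogen, gives > 3000 nM as a limit of the assay and not a number. The earlier compounds shown here only swapped one chain for another, whereas here hydrogen replaces the whole chain and inhibition is weaker than with 3-methoxypropyl (an at least 3.4-fold higher number from compound 3 to compound 4 (0.54 log units; beyond the scatter)), 2-(ethylamino)ethyl (an at least 10-fold higher number from compound 2 to compound 4 (1.01 log units; beyond the scatter)) and 2-ethoxyethyl (an at least 300-fold higher number from compound 1 to compound 4 (2.47 log units; beyond the scatter)). Each of these three chains on this nitrogen therefore gives stronger inhibition than hydrogen does. From the compounds shown here alone, how a short methyl group or a chain ending in a carboxylic acid would compare remains open. So does how far beyond its limit compound 4 lies.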